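The source may hold more compounds than are shown below. What is called first, only, known or untested is meant among the compounds shown, and "the series" means these compounds.

Compound 3 `CCOC(=O)CCCCCOc1cccc(CN(C(=O)c2ccc(-c3cccc(OC(C)C)c3)cc2)C(C)C)c1` is the starting point. In an ADME assay on Raji cells (Homo sapiens) for cytotoxicity, read by CellTiter-Glo and resazurin assay, with a stated time of 72 h (a lower number here means that less compound is needed, a higher number that more compound is needed for the effect), compound 3 gives > 26000 nM, which is a limit of the assay rather than a number. Compound 1 `CC(C)Oc1cccc(-c2ccc(C(=O)N(Cc3cccc(OCCCCCC(=O)O)c3)C(C)C)cc2)c1` in this assay gives > 26000 nM, also a limit. Compound 2 `CCOC(=O)CCCCCOc1cccc(CN(C(=O)c2ccc(-c3cccc(OCC(C)C)c3)cc2)C(C)C)c1` in this assay gives > 26000 nM, again a limit. All three values sit at the limit of > 26000 nM in this assay, at which 3 of the 3 values shown sit, so compound 3 stands level with the other two and no ordering among them can be read. The step that the two limits leave unreadable from compound 1 to compound 3 cannot be read, and neither can a step that the two limits leave unreadable from compound 2 to compound 3. Compound 4 `CCOC(=O)CCCCCOc1cccc(CN(C(=O)c2ccc(-c3cccc(Br)c3)cc2)C(C)C)c1` differs from compound 3 by bromo in place of isopropoxy on an aromatic carbon. For the measured compounds named here, no measured step bears on that change, and the two steps that are known, both unreadable, give no size to expect in this assay in either direction. Going by the values given here, what the data show is only that every measured compound reaches the limit. Compound 4 is therefore expected to remain near that limit, with a number no higher from compound 3 to compound 4 (the limit leaves the size open) estimated as no readable change. For compound 4 in this assay the estimate is 26000 nM, with a range from 8000 nM to 80000 nM.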

Compound 4, half-maximal effective concentration: > 26000 nM
Compound 4: no number, only a limit (the forecaster's own chance of this, stated with the estimate: 70%); the middle value sits exactly at the limit.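

Compound 4 also sits at a limit, so the steps to it from compound 2 and compound 3 cannot be read, and no new step emerges: the limit of > 26000 nM in this assay, at which 4 of the 4 values shown sit.

The compounds shown leave open whether bromo or isopropoxy changes the true value in this assay at all.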